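A few compounds are considered here, and "the series" means these few. Any claim that something is new, unique, unknown or untested is made for them only; others in the source may bear on it.

Measured compounds in a functional assay on HEK293 cells for antagonist activity at proteinase-activated receptor 4 (Homo sapiens), read by FLIPR and calcium flux, with a stated time of 30 min; a lower number here means a stronger inhibitor, a higher number a weaker inhibitor: compound 1 `CCOc1nn2cc(-c3cc4ccccc4o3)nc2s1` gives 67 nM; compound 2 `COc1cc(OCc2cccc(CCc3ccccc3)c2)c2cc(-c3cn4nc(OC)sc4n3)oc2c1` gives 2.4 nM; compound 3 `COc1cc(OCc2cccc(C#N)c2)c2cc(-c3cn4nc(OC)sc4n3)oc2c1` gives 0.98 nM.

Compound 3 has the lowest number of the three in this assay, with compound 2 nearest and compound 1 furthest. For the measured compounds named here, the one single-point step known, a 2.4-fold lower number from compound 2 to compound 3 (0.39 log units; beyond the scatter), is modest. Compound 4 `COc1cc(OCc2cccc(O)c2)c2cc(-c3cn4nc(OC)sc4n3)oc2c1` differs from compound 3 by hydroxy in place of cyano on an aromatic carbon. Going by the values given here, no measured pair shows hydroxy against cyano, so the step from compound 2 to compound 3 only shows that the group on this aromatic carbon moves the number modestly. Compound 4 is therefore expected to stay near compound 3, with a small step of a 2.0-fold higher number from compound 3 to compound 4 (0.31 log units; beyond the scatter) toward a higher number, and is estimated at 2 nM with a range of 0.6 nM to 7 nM.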

Compound 4, half-maximal inhibitory concentration: 3.1 nM
The estimate for compound 4 lay 1.6-fold (0.19 log units) below the measured number, within the range that was stated.
By their numbers in this assay, from the lowest: compound 3; then compounds 2 and 4 (each within the scatter of the next); then compound 1.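

In this assay, the step of a 3.2-fold higher number from compound 3 to compound 4 (0.50 log units; beyond the scatter) is modest but beyond the scatter, so cyano and hydroxy can be told apart on this aromatic carbon. The step of a 1.3-fold higher number from compound 2 to compound 4 (0.11 log units; within the scatter) lies within the scatter, so hydroxy and phenethyl cannot be separated here, despite the difference in size between the two groups. Nothing measured alongside these numbers bears on the reason for this pattern.

Going by these compounds, whether an amine, a carboxylic acid or a methoxy group at this place would fall nearer compound 3 or compound 4 remains open. Also open, on these data alone, is whether the gap between cyano and hydroxy persists on a different core.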